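The source may report more compounds than this note shows. Statements on the series, on what has been measured and on what is new or still open speak of the compounds shown alone.

Compound 1 `CC(C)CNc1nc(N)nc2c1ncn2/C=C1/CC1(CO)CO`: > 20000 nM
Compound 2 `CCCCCCSc1nc(N)nc2c1ncn2/C=C1/CC1(CO)CO`: 60000 nM
Compound 3 `CC(C)Sc1nc(N)nc2c1ncn2/C=C1/CC1(CO)CO`: 94000 nM

In an ADME assay on CCRF-HSB-2 cells (Homo sapiens) for cytotoxicity, with a stated time of 7 days (on this read-out higher numbers stand for lower toxicity in this test and lower numbers for higher toxicity in this test), compound 1 gives > 20000 nM, which is a limit of the assay and not a number. Compound 2 gives 60000 nM and compound 3 gives 94000 nM, with a 1.6-fold higher number from compound 2 to compound 3 (0.19 log units; within the scatter) between them. The steps a step that the limit leaves unreadable from compound 1 to compound 2 and a step that the limit leaves unreadable from compound 1 to compound 3 cannot be sized because the limit of > 20000 nM in this assay, at which 1 of the 3 values shown sits, hides the starting value. Compound 4 `CNc1nc(N)nc2c1ncn2/C=C1/CC1(CO)CO` differs from compound 1 by hydrogen in place of isopropyl on a saturated chain carbon bound to a nitrogen on an aromatic ring. Within the data shown here, no measured step touches this change, and the two readable measured compounds both sit far from toxicity, so no move beyond the scatter is anticipated. Compound 4 is expected at 30000 nM, with a range from 10000 nM to 100000 nM, and most likely again as a limit. This estimate corresponds to a step that the limit leaves unreadable from compound 1 to compound 4.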

Compound 4, half-maximal cytotoxic concentration: > 20000 nM
Compound 4 gave a limit, no number; the forecaster's own chance of this, stated with the estimate: 65%; the middle value does not contradict the limit.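

Compound 4 gives > 20000 nM, a limit and not a number. No step from compound 1, compound 2 or compound 3 to compound 4 can be read in this assay: the limit of > 20000 nM in this assay, at which 2 of the 4 values shown sit.

Still open, going by these compounds, is how the methylamino of compound 4 and the isobutylamino of compound 1 compare with each other and with the sulfanyl groups of compound 2 and compound 3.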